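Swapping the Sulfonyl Aryl Group on a Glutamate Receptor Binder

A few compounds are considered here, and "the series" means these few. Any claim that something is new, unique, unknown or untested is made for them only; others in the source may bear on it.

Compound 1 `COc1ccc(S(=O)(=O)c2cnc3ccc(Cl)cc3c2N2CCC(C)CC2)cc1Cl` has the higher of the two measured numbers: in an assay on isolated protein for displacement of a labelled ligand from metabotropic glutamate receptor 5 (Homo sapiens), with a stated time of 60 min, tested at 1 uM (on this read-out lower numbers stand for less inhibition and higher numbers for more inhibition at the one concentration tested (going by the name of the read-out)), compound 1 gives 46%, while compound 2 `COc1ccc2ncc(S(=O)(=O)c3ccc(OC)c(Cl)c3)c(N3CCC(C)CC3)c2c1` gives 21%. Within the data shown here, the only measured step, a number 25 percentage points lower from compound 1 to compound 2 (beyond the scatter), changes the shared core and not the sulfonyl aryl group. Compound 3 `CC1CCN(c2c(S(=O)(=O)c3cccc(C#N)c3)cnc3ccc(Cl)cc23)CC1` differs from compound 1 by 3-cyanophenyl in place of 3-chloro-4-methoxyphenyl on a sulfonyl sulfur. Among the measured compounds shown here, no measured step touches this part of the molecule, so no direction can be read from the data, and a step of uncertain sign is expected. Compound 3 is estimated at 38%, within 10% to 68%, an expected step of a number 8 percentage points lower from compound 1 to compound 3 (within the scatter).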

Compound 3, a percentage reported as inhibition, at one concentration (the size of the read-out at that concentration, not a potency): 90%
Compound 3: the middle estimate sits 52 percentage points below what was measured; the measured number lies above the stated range.
By their numbers in this assay, from the lowest: compound 2; then compound 1; then compound 3.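

The group on the sulfonyl sulfur has a large influence in this assay, with 3-cyanophenyl in place of 3-chloro-4-methoxyphenyl giving a number 44 percentage points higher from compound 1 to compound 3 (beyond the scatter). The earlier step changed only the shared core, so it gave no reading of this position. No measurement available gives a reason for this rise.

Going by these compounds, whether the nitrile itself or the loss of the chloro and methoxy groups drives the step remains open, as the swap changes all three at once. On these data alone, how a carboxylic acid or a primary amide on this phenyl ring would compare also remains open.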